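Paw edema series: pyridin-3-yl amide replacing the anilide

The compounds below may be only part of what the source reports. "The series", "measured", "known", "first", "only" and "open" are said of these compounds alone.

Two members of the series carry measured numbers. Compound 1 `O=C(NC1CCN(Cc2ccccc2)CC1)c1c(O)c2cccnc2n(-c2ccccc2)c1=O` gives 1.2% in a functional assay on the whole organism for inhibition, with Rattus norvegicus as the target, read by cytopathic effect and paw edema, at a dose of 100 mg/kg by the oral route; on this read-out higher numbers stand for more inhibition at the one dose given (going by the name of the read-out) and lower numbers for less inhibition. Compound 2 `O=C(Nc1ccccc1)c1c(O)c2cccnc2n(-c2ccccc2)c1=O` gives -15% in this assay, the lower of the two numbers, and compound 1 sits higher by a gap that lies beyond the scatter. Neither number amounts to marked inhibition.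

The next step goes from compound 2 to compound 3 `O=C(Nc1cccnc1)c1c(O)c2cccnc2n(-c2ccccc2)c1=O`. The change is pyridin-3-yl in place of phenyl on an amide-type nitrogen. Among the compounds with values here, no measured pair shows this change, so its effect is unknown from the series itself.

The expectation rests only on the two numbers above. Compound 3 is estimated to show little change because compound 2 gives -15% and the shared core with an aromatic amide substituent has so far produced no real inhibition. The expected step is a number 10 percentage points higher from compound 2 to compound 3 (within the scatter), no step beyond the scatter. Compound 3 is estimated at -5%, with a range from -25% to 15%.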

Compound 3, a percentage reported as inhibition, in the whole organism at one dose (the size of the read-out at that dose, not a potency): 30.8%
Compound 3: middle estimate off by 35.8 percentage points, on the low side; measured number outside the range, above it.
By their numbers in this assay, from the lowest: compound 2; then compound 1; then compound 3.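

In this assay, pyridin-3-yl in place of phenyl on an amide-type nitrogen gives a number 45.8 percentage points higher from compound 2 to compound 3 (beyond the scatter), so an aromatic amide substituent on the shared core does not by itself rule out inhibition at the one dose given. The position responds strongly to a small change: both groups have the same heavy-atom count, yet one ring carbon exchanged for nitrogen, adding one hydrogen-bond acceptor, separates the two compounds. Nothing available accounts for this step.

Going by these compounds, whether the result depends on where the ring nitrogen sits remains open, and pyridin-2-yl and pyridin-4-yl amides would address that. Also open, on these data alone, is whether the step holds for a pyrimidin-5-yl group, or for a methyl or chloro group on the pyridin-3-yl ring.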